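Biaryl swap to 2-aminophenyl in the purine-free notes

The source may hold more compounds than are shown below. What is called first, only, known or untested is meant among the compounds shown, and "the series" means these compounds.

Values in a functional assay on G-361 cells (Homo sapiens) for inhibition, with a stated time of 72 h; a higher number here means a weaker inhibitor, a lower number a stronger inhibitor:
- compound 1 `NC1CCC(Nc2nc(NCc3ccc(-c4ccsc4)cc3)c3ncn(C4CCCC4)c3n2)CC1`: 570 nM
- compound 2 `NC1CCC(Nc2nc(NCc3ccc(-c4ccccc4)nc3)c3ncn(C4CCCC4)c3n2)CC1`: 895 nM
- compound 3 `NC1CCC(Nc2nc(NCc3ccc(-c4ccccc4O)nc3)c3ncn(C4CCCC4)c3n2)CC1`: 24 nM

Compound 2 sits at the high-number end of this short set, together with compound 1. The two are not separated, as the step of a 1.6-fold higher number from compound 1 to compound 2 (0.20 log units; within the scatter) shows. Compound 3 lies well away from both, through the large step of a 37-fold lower number from compound 2 to compound 3 (1.57 log units; beyond the scatter).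

The next entry is compound 4 `Nc1ccccc1CNc1nc(NC2CCC(N)CC2)nc2c1ncn2C1CCCC1`, with 2-aminophenyl in place of 6-phenylpyridin-3-yl on a saturated chain carbon bound to a nitrogen on an aromatic ring.

Going by the values given here, two measured steps bear on this only in part. Exchanging one two-ring group for another in compound 2 gave a 1.6-fold higher number from compound 1 to compound 2 (0.20 log units; within the scatter), which suggests some tolerance at this place. Adding hydroxy to the outer ring in compound 3 gave a 37-fold lower number from compound 2 to compound 3 (1.57 log units; beyond the scatter), but that group is absent from compound 4, and an amino group on a single ring is a different change. Among the compounds with values here, no measured step removes a ring, so the uncertainty is wide.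

In this assay the estimated step is a 1.8-fold lower number from compound 2 to compound 4 (0.25 log units; within the scatter), so no change beyond the scatter is expected.

For compound 4 the estimated value is 500 nM, with an expected range of 100 nM to 2500 nM.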

Compound 4, half-maximal inhibitory concentration: 2070 nM
For compound 4 the middle estimate is 4.1-fold (0.62 log units) below the measured one, and the stated range covers the measured number.
By their numbers in this assay, from the lowest: compound 3; then compounds 1 and 2 (each within the scatter of the next); then compound 4.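

In this assay, going by these compounds alone, 2-aminophenyl is the first replacement on this saturated chain carbon bound to a nitrogen on an aromatic ring to move the number beyond the scatter, with a 2.3-fold higher number from compound 2 to compound 4 (0.36 log units; beyond the scatter) and a 3.6-fold higher number from compound 1 to compound 4 (0.56 log units; beyond the scatter) as the two steps. The tolerance seen between the two-ring groups 6-phenylpyridin-3-yl and 4-(thiophen-3-yl)phenyl therefore does not extend to this smaller single-ring group, although both steps are modest beside the large 37-fold lower number from compound 2 to compound 3 (1.57 log units; beyond the scatter) on hydroxy addition. The change removes a ring and brings in an amino group at once, so the compounds cannot apportion the step between the two, and no measurement is available to explain it.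

Plain phenyl at this place would separate the loss of the ring from the effect of the amino group. Also open, from the compounds shown here alone, is whether hydroxy keeps its large effect away from the two-ring group, which 2-hydroxyphenyl on the same chain carbon would test, and whether an aminomethyl group on the single ring would behave like the amino group of compound 4.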